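Cytotoxicity notes: phenyl in place of hydroxymethyl

A few compounds are considered here, and "the series" means these few. Any claim that something is new, unique, unknown or untested is made for them only; others in the source may bear on it.

Measured so far:
Compound 1 `CC1(Cc2ccc([N+](=O)[O-])cc2)CC(S(=O)(=O)c2ccc(F)cc2)=C(c2ccc(/C(N)=N/O)cc2)O1` gives 97400 nM in an ADME assay on cells (Peritoneal macrophage, Mus musculus, strain Balb/c) for cytotoxicity, read by resazurin assay, with a stated time of 72 h; a lower number here means that less compound is tolerated, a higher number that more compound is tolerated.
Compound 2 `COc1cc(CC2(C)CC(S(=O)(=O)c3ccc(F)cc3)=C(c3ccc(/C(N)=N/O)cc3)O2)cc(OC)c1OC` gives 92300 nM in this assay.
Compound 3 `CC1(Cc2ccc(CO)cc2)CC(S(=O)(=O)c2ccc(F)cc2)=C(c2ccc(/C(N)=N/O)cc2)O1` gives > 100000 nM in this assay; this is a limit of the assay and not a number.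

From the compounds shown here alone, compound 3 thus stands only at the floor of the measured range, at the limit of > 100000 nM in this assay, at which 1 of the 3 values shown sits, and its true value beyond that limit is unknown. The step under consideration leads to compound 4 `CC1(Cc2ccc(-c3ccccc3)cc2)CC(S(=O)(=O)c2ccc(F)cc2)=C(c2ccc(/C(N)=N/O)cc2)O1`, and the change is phenyl in place of hydroxymethyl on an aromatic carbon.

All measured steps concern the same aryl group on the saturated chain carbon: a 1.1-fold lower number from compound 1 to compound 2 (0.02 log units; within the scatter), an at least 1.0-fold higher number from compound 1 to compound 3 (0.01 log units; that floor lies within the scatter), an at least 1.0-fold higher number from compound 2 to compound 3 (0.03 log units; that floor lies within the scatter). None of them moved this assay beyond the scatter, whether the group carried nitro, three methoxy groups or hydroxymethyl. Within the data shown here, no measured step introduces phenyl, so the change to compound 4 lies outside what the measured steps cover; what they do show is that variation at this position has left this assay flat across three compounds.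

The expectation for compound 4 is therefore no step beyond the scatter, with a substantial chance that it again sits at the limit. Compound 4 is estimated at 95000 nM, with a range from 55000 nM to 160000 nM. The expected step is an at least 1.0-fold lower number from compound 3 to compound 4 (0.02 log units; that floor lies within the scatter), essentially flat.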

Compound 4, half-maximal cytotoxic concentration: 33900 nM
The estimate for compound 4 lay 2.8-fold (0.45 log units) above the measured number; measured number below the stated range.
By their numbers in this assay, from the lowest: compound 4; then compounds 2 and 1 (each within the scatter of the next). At a limit, above all of these: compound 3.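

Among these compounds, in (this assay) this position is no longer flat: phenyl in place of hydroxymethyl gives the first step beyond the scatter (an at least 2.9-fold lower number from compound 3 to compound 4 (0.46 log units; beyond the scatter)), and the steps from the other two compounds are also beyond it (a 2.7-fold lower number from compound 2 to compound 4 (0.44 log units; beyond the scatter); a 2.9-fold lower number from compound 1 to compound 4 (0.46 log units; beyond the scatter)). Nitro, three methoxy groups and hydroxymethyl had left compounds 1, 2 and 3 with no separation beyond the scatter, so compound 4, with its 4-phenylphenyl group, is the first compound shown to stand apart, and it has the lowest number of the four. From the compounds shown here alone, compound 3 is held only as a limit, so the step from it is a floor and its true size stays unknown: (the limit of > 100000 nM in this assay, at which 1 of the 4 values shown sits).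

The compounds shown do not tell whether a cyclohexyl ring, a benzyl group or a longer alkyl chain in this place would lower the number as phenyl does, or whether an amine or a carboxylic acid on the added phenyl ring would raise it again. Among the compounds shown here, with compound 4 as the only compound carrying the added ring, the drop is a single observation, and its cause remains open.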